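The source may hold more compounds than are shown below. What is called first, only, known or untested is meant among the compounds shown, and "the series" means these compounds.

In a functional assay on MCF7 cells (Homo sapiens) for inhibition, read by MTT assay, with a stated time of 72 h (on this read-out higher numbers stand for weaker inhibition and lower numbers for stronger inhibition), compound 1 `CC(C)C(=O)N1CCN(c2nnc3nncn3n2)CC1` gives 1810 nM. Within the data shown here, compound 2 `c1nnc2nnc(NC3CCCCC3)nn12` gives 3510 nM, and these two values lie within the usual scatter of each other, so compound 1 stands level with the only other true number available. Compound 3 `CC(Nc1nnc2nncn2n1)C(=O)O` gives no true number, only a limit of the assay, > 100000 nM.

Compound 4 `CC(C)COC(=O)N1CCN(c2nnc3nncn3n2)CC1` has not yet been measured. It keeps the core of compound 1 and carries isobutoxy in place of isopropyl on a carbonyl carbon, so isopropylcarbonyl becomes isobutoxycarbonyl.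

Among the measured compounds shown here, no measured pair shows this swap, so the guidance is thin. Compound 1 at 1810 nM and compound 2 at 3510 nM carry different groups on the shared core yet stay within the scatter, although compound 3 goes against this picture. No step beyond the scatter is therefore expected in this assay. The expected step is a 1.4-fold higher number from compound 1 to compound 4 (0.14 log units; within the scatter). For compound 4 the estimated value is 2500 nM, with an expected range from 600 nM to 10000 nM.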

Compound 4, half-maximal inhibitory concentration: 5390 nM
Beside the measured number, compound 4's estimate is 2.2-fold (0.33 log units) below it; low and high end bracket the measured number.
By their numbers in this assay, from the lowest: compounds 1, 2 and 4 (each within the scatter of the next, the first and the last beyond it). At a limit, above all of these: compound 3.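

Among these compounds, the change from isopropylcarbonyl to isobutoxycarbonyl is the first change in a single place in this set, and in this assay it gives a 3.0-fold higher number from compound 1 to compound 4 (0.47 log units; beyond the scatter) and so shows that the number responds to what sits on this carbonyl carbon. The step is modest, so isobutoxy remains compatible with a measurable value in this assay, but it does not match isopropyl here. None of the information at hand explains why the number moves with this swap.

The compounds shown leave open whether the step follows the added oxygen or the added carbons, a question that an isopropoxy or an isobutyl group on the same carbonyl carbon would help to separate. On these data alone, how an amine or a ring such as cyclohexyl would behave at this place also remains open.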